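Trifluoromethyl in place of methoxymethyl: a clearance estimate

The compounds below may be only part of what the source reports. "The series", "measured", "known", "first", "only" and "open" are said of these compounds alone.

Measured in an ADME assay (liver) for pharmacokinetics, with Liver microsome (Rattus norvegicus) as the target, read by LC-MS, using microsomes, tested at 2 uM; a higher number here means faster removal of the compound, a lower number slower removal:
compound 1 `O=C(N[C@@H]1CCCC[C@H]1O)c1cnc(OCC2CC2)c(-c2ccc(Cl)cc2)c1`: 0.064 mL/min/kg
compound 2 `COCCOc1ncc(C(=O)N[C@@H]2CCCC[C@H]2O)cc1-c1ccc(Cl)cc1`: 0.098 mL/min/kg

In this small set, compound 2 stands at 0.098 mL/min/kg, within the scatter of compound 1. Compound 3 `O=C(N[C@@H]1CCCC[C@H]1O)c1cnc(OCC(F)(F)F)c(-c2ccc(Cl)cc2)c1` has not yet been measured. It carries trifluoromethyl in place of methoxymethyl on a saturated chain carbon bound to an oxygen on an aromatic ring. Going by the values given here, only one measured step changes this same place, a 1.5-fold higher number from compound 1 to compound 2 (0.19 log units; within the scatter), so no shift beyond the scatter is expected in this assay. The expected step is a 1.4-fold lower number from compound 2 to compound 3 (0.15 log units; within the scatter). Compound 3 is estimated at 0.07 mL/min/kg, with an expected range of 0.03 mL/min/kg to 0.16 mL/min/kg.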

Compound 3, clearance: 0.023 mL/min/kg
For compound 3 the middle estimate is 3.0-fold (0.48 log units) above the measured one, outside the stated range (below it).
By their numbers in this assay, from the lowest: compound 3; then compounds 1 and 2 (each within the scatter of the next).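

In this assay this position proves able to move the number beyond the scatter, which the step between compounds 1 and 2 did not show. Trifluoromethyl gives a lower number than methoxymethyl (a 4.3-fold lower number from compound 2 to compound 3 (0.63 log units; beyond the scatter)) and than cyclopropyl (a 2.8-fold lower number from compound 1 to compound 3 (0.44 log units; beyond the scatter)), leaving compound 3 the lowest of the three. Nothing available here explains this shift.

The compounds shown leave open how an amine, a carboxylic acid or a longer chain at this place would compare. They also leave open whether a single fluorine would give a similar step.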